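This account rests on a few compounds, and the source may have more. Where it says the series, first, only, none or still open, it means among the compounds named here.

Measured so far in a functional assay on BXPC-3 cells (Homo sapiens) for antiproliferative activity, read by MTT assay, with a stated time of 24 h; on this read-out higher numbers stand for weaker inhibition and lower numbers for stronger inhibition:
Compound 1 `CCn1c(C(=O)N[C@@H](C)C(=O)OC)ccc1C(CC)(CC)c1ccc(OCS(=O)(=O)c2ccccc2)c(C)c1` gives 17900 nM.
Compound 2 `CCn1c(C(=O)NCCC(=O)OC)ccc1C(CC)(CC)c1ccc(OCS(=O)(=O)c2ccccc2)c(C)c1` gives only a limit, > 50000 nM.
Compound 3 `CCN(CC)CCNC(=O)c1ccc(C(CC)(CC)c2ccc(OCS(=O)(=O)c3ccccc3)c(C)c2)n1CC` gives 6270 nM.

Of the two real numbers, compound 1 has the higher one, that is the weaker inhibition; compound 3 sits below it by a 2.9-fold lower number from compound 1 to compound 3 (0.46 log units; beyond the scatter). Compound 4 `CCn1c(C(=O)N[C@@H](C)C(=O)O)ccc1C(CC)(CC)c1ccc(OCS(=O)(=O)c2ccccc2)c(C)c1` has not yet been measured. It differs from compound 1 in a single place: hydrogen in place of methyl on an oxygen next to a carbonyl group. For the measured compounds named here, none of the measured steps touches that oxygen. Both steps seen, an at least 2.7-fold higher number from compound 1 to compound 2 (0.44 log units; beyond the scatter) and a 2.9-fold lower number from compound 1 to compound 3 (0.46 log units; beyond the scatter), change the group carried on the amide-type nitrogen, so they do not speak to this change. With nothing to lean on, the expected step is a 1.1-fold higher number from compound 1 to compound 4 (0.05 log units; within the scatter), within the scatter. The estimate for compound 4 is therefore 20000 nM, with a range from 8000 nM to 50000 nM.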

Compound 4, half-maximal inhibitory concentration: 20800 nM
Estimate against measurement, compound 4: 1.0-fold (0.02 log units) below; measured number inside the range.
By their numbers in this assay, from the lowest: compound 3; then compounds 1 and 4 (each within the scatter of the next). At a limit, above all of these: compound 2.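

Methoxycarbonyl to carboxy is the first change shown at this oxygen, and in this assay it stays within the scatter, with a 1.2-fold higher number from compound 1 to compound 4 (0.07 log units; within the scatter). Compound 4, like compound 1, still falls short of the 2-(diethylamino)ethyl group, with a 3.3-fold higher number from compound 3 to compound 4 (0.52 log units; beyond the scatter). Compound 2 gives only a limit, so an at least 2.4-fold lower number from compound 2 to compound 4 (0.38 log units; beyond the scatter) is a bound and not an exact size: the limit of > 50000 nM in this assay, at which 1 of the 4 values shown sits.

As far as these compounds go, it remains open whether an ethyl ester or a primary amide in place of methoxycarbonyl would behave the same way. From the compounds shown here alone, it also remains open whether the same methyl-to-hydrogen change would matter on the 2-(methoxycarbonyl)ethyl group of compound 2.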